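A Pyridine Methyl Removed on a Second Pyrazoline Core

This account rests on a few compounds, and the source may have more. Where it says the series, first, only, none or still open, it means among the compounds named here.

Three pyrazoline amides have been measured in a functional assay on WM 266-4 cells (Homo sapiens) for antiproliferative activity, read by MTT assay, with a stated time of 24 h; on this read-out lower numbers stand for stronger inhibition of growth and higher numbers for weaker inhibition of growth. Compound 1 `COc1ccc(C2=NN(C(=O)c3ccc(C)nc3Cl)C(c3ccc(OC)cc3)C2)cc1` gives 5740 nM in this assay. Compound 2 `COc1ccc(C2=NN(C(=O)c3cccnc3Cl)C(c3ccc(OC)cc3)C2)cc1`, which carries hydrogen in place of methyl on an aromatic carbon, gives 4350 nM in this assay, and the step of a 1.3-fold lower number from compound 1 to compound 2 (0.12 log units; within the scatter) lies within the scatter of repeated measurements. Compound 3 `Cc1ccc(C(=O)N2N=C(c3ccc(Cl)cc3)CC2c2ccc(Br)cc2)c(Cl)n1` gives 10800 nM in this assay; its value is the highest of the three, though its gap to compound 1 is within the scatter, while its gap to compound 2 is beyond it. The difference between the core of compound 3 and the core of compound 1 is not broken down here.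

Compound 4 `O=C(c1cccnc1Cl)N1N=C(c2ccc(Cl)cc2)CC1c1ccc(Br)cc1` has not yet been measured. It differs from compound 3 by hydrogen in place of methyl on an aromatic carbon, and this is the same change as the one from compound 1 to compound 2, made at a place described in identical terms; it is the only other occurrence of that change among the compounds shown. Because the step of a 1.3-fold lower number from compound 1 to compound 2 (0.12 log units; within the scatter) was small, compound 4 is expected to stay close to compound 3, and the expected step is a 1.3-fold lower number from compound 3 to compound 4 (0.11 log units; within the scatter) in this assay. On that basis compound 4 is estimated to give 8300 nM in this assay, with a likely range from 4000 nM to 17000 nM. This estimate rests on a single earlier occurrence of the change, on a different core, so it is held loosely until compound 4 is measured.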

Compound 4, concentration for 50% growth inhibition: 7450 nM
For compound 4 the middle estimate is 1.1-fold (0.05 log units) above the measured one, within the range that was stated.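

Exchanging the 2-chloro-6-methylpyridin-3-yl group for 2-chloropyridin-3-yl on the core of compound 3 gives a 1.4-fold lower number from compound 3 to compound 4 (0.16 log units; within the scatter) in this assay, a small step like the one seen earlier on the core of compound 1. Set side by side, the two steps do not differ, so in this assay the change carries from one core to the other with no detectable dependence on the core: the same change on two cores in this assay, a 1.3-fold lower number (0.12 log units; within the scatter) from compound 1 to compound 2 and a 1.4-fold lower number (0.16 log units; within the scatter) from compound 3 to compound 4, 1.1-fold (0.04 log units) apart, within the scatter of two such steps This does not show that the methyl group has any real effect on growth inhibition, since each step on its own lies within the scatter, and agreement between two small steps on two cores says nothing about how the change would behave on any further core.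

The compounds shown leave open whether a larger change at the same place, with an amine, a methoxy group or a longer chain such as propyl in place of the methyl, would move the number beyond the scatter on either core. They also leave open what the chloro group contributes, as it stays in place in all four compounds, and how much of the difference between the two cores comes from each of their aromatic groups.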